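This account rests on a few compounds, and the source may have more. Where it says the series, first, only, none or still open, it means among the compounds named here.

Compound 1 `O=C1C=C(NC2CCCCC2)C(=O)c2c1nc1n2[C@H]2OC[C@@H](O)[C@H]2OC1` stands in a functional assay on HeLa cells (Homo sapiens) for inhibition, read by sulforhodamine B assay (a higher number here means a weaker inhibitor, a lower number a stronger inhibitor), at > 16000 nM, which is a limit of the assay and not a number.
Compound 2 `O=C1C(N2CCCC2)=CC(=O)c2c1nc1n2[C@H]2OC[C@@H](O)[C@H]2OC1` stands in this assay at > 16000 nM, again a limit of the assay rather than a number.
Compound 3 `O=C1C(NC2CC2)=CC(=O)c2c1nc1n2[C@H]2OC[C@@H](O)[C@H]2OC1` stands in this assay at > 16000 nM, once more a limit of the assay rather than a number.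

Compound 1 therefore has no number of its own in this assay, and the two further values shown are limits as well: the limit of > 16000 nM in this assay, at which 3 of the 3 values shown sit. The change that leads from compound 1 to compound 4 `O=C1C=C(N2CCCC2)C(=O)c2c1nc1n2[C@H]2OC[C@@H](O)[C@H]2OC1` is pyrrolidin-1-yl in place of cyclohexylamino on a double-bonded ring carbon. Among the measured compounds shown here, the only measured step that bears on it is a step that the two limits leave unreadable from compound 2 to compound 3, which the two limits leave unreadable, so its size is unknown. Compound 2 already carries the pyrrolidin-1-yl that enters compound 4 and sits at the limit, and compound 1, with the cyclohexylamino that leaves, sits at the limit too. For the measured compounds named here, no measured step here gives a direction or a size, and the author expects no readable step in this assay for compound 4 either, most likely another limit. The step from compound 1 to compound 4 is estimated as a step that the limit leaves unreadable from compound 1 to compound 4. Compound 4 is expected at 30000 nM, within the range 10000 nM to 100000 nM.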

Compound 4, half-maximal inhibitory concentration: > 16000 nM
Compound 4 was reported as a limit; the forecaster's own chance of this, stated with the estimate: 85%; the middle value is on the limit's open side.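

In this assay compound 4 gives > 16000 nM, a limit of the assay and not a number. Among the compounds shown here, compound 1 also sits at a limit, so no step from compound 1 to compound 4 can be read. The values shown all end at one limit: the limit of > 16000 nM in this assay, at which 4 of the 4 values shown sit.

The compounds shown leave open how strongly any of them inhibits in this assay, and whether pyrrolidin-1-yl in place of cyclohexylamino makes any difference there.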